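The source may hold more compounds than are shown below. What is called first, only, known or untested is meant among the compounds shown, and "the series" means these compounds.

In a functional assay on A2780 cells (Homo sapiens) for cytotoxicity, read by MTT assay, with a stated time of 72 h (a higher number here means a weaker inhibitor, a lower number a stronger inhibitor), three compounds that share a sulfonamide linking a methyl-substituted benzene to a bicyclic core have been measured. Compound 1 `Cc1ccc(S(=O)(=O)Nc2cccc3c2cnn3C)cc1` gives 6620 nM, and compound 2 `CCOc1ccc(NS(=O)(=O)c2ccc(C)cc2)c2cn(C)nc12` gives 8340 nM. Compound 3 `Cc1ccc(S(=O)(=O)Nc2ccc3c[nH]nc3c2)cc1`, which keeps the hydrogen on the ring nitrogen of its core rather than a methyl group, gives 86600 nM, the highest of the three numbers and therefore the weakest inhibitor of the set; its gap to compound 2 and to compound 1 lies beyond the usual scatter in each case. The step to compound 4 `C=CCn1cc2ccc(NS(=O)(=O)c3ccc(C)cc3)cc2n1` changes one thing: allyl in place of hydrogen on an aromatic nitrogen. Going by the values given here, no measured pair in the set isolates this exact change, so the size of the step can only be guessed. Since the two compounds that carry a group instead of hydrogen on that nitrogen, compound 1 and compound 2, sit well below compound 3 in this assay, a move toward stronger inhibition is expected, though their cores also differ in where the sulfonamide is attached. The expected step from compound 3 to compound 4 is a 4.3-fold lower number from compound 3 to compound 4 (0.64 log units; beyond the scatter), an improvement beyond the scatter. Compound 4 is estimated to give about 20000 nM, within a range of 5000 nM to 60000 nM.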

Compound 4, half-maximal inhibitory concentration: 4890 nM
For compound 4 the middle estimate is 4.1-fold (0.61 log units) above the measured one, outside the stated range (below it).
By their numbers in this assay, from the lowest: compounds 4, 1 and 2 (each within the scatter of the next); then compound 3.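

In this assay, allyl in place of hydrogen on an aromatic nitrogen gives an 18-fold lower number from compound 3 to compound 4 (1.25 log units; beyond the scatter). Compound 1 and compound 2 each differ from compound 3 in more than one place, whereas this pair differs in that place alone, showing directly that the hydrogen on this nitrogen is not needed for activity in this cell assay and that replacing it with allyl is enough to produce a large gain. The data shown offer no measurement that explains why this change has such an effect.

From the compounds shown here alone, it remains open whether the double bond of allyl matters, which a saturated propyl chain on the same nitrogen would test. It is also unclear how far this position tolerates larger groups, such as a benzyl group or a longer chain ending in an amine.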